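Succinimide amides in the maximal electroshock model

The compounds below may be only part of what the source reports. "The series", "measured", "known", "first", "only" and "open" are said of these compounds alone.

Compound 1 `CCC(C(=O)N1CCN(c2cccc(C(F)(F)F)c2)CC1)N1C(=O)CCC1=O` gives 50% in a functional assay on the whole organism (strain Swiss) with Mus musculus as the target, in the maximal electroshock model, with a stated time of 0.5 h, at a dose of 300 mg/kg by the intraperitoneal route; on this read-out higher numbers stand for a stronger effect at the one dose given and lower numbers for a weaker effect.
Compound 2 `CC(C(=O)N1CCOCC1)N1C(=O)CCC1=O` gives 0% in this assay.
Compound 3 `CCC(C(=O)N1CCOCC1)N1C(=O)CCC1=O` gives 0% in this assay.

Compound 1 stands highest of the three; compound 2 and compound 3 each sit below it by a distance beyond the scatter. Between compound 3 and compound 2 the change is hydrogen in place of methyl on a saturated chain carbon, two bonds along the chain from an amide-type nitrogen in a ring and a carbonyl carbon, and the step of no change at the digits printed from compound 3 to compound 2 (within the scatter). Both ends of that step lie at zero in this assay, so it shows nothing of what the change does where activity is present. The difference between the core of compound 1 and the core of compound 3 is not broken down here.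

Compound 4 `CC(C(=O)N1CCN(c2cccc(C(F)(F)F)c2)CC1)N1C(=O)CCC1=O` is not yet measured. It differs from compound 1 by hydrogen in place of methyl on a saturated chain carbon, two bonds along the chain from an amide-type nitrogen in a ring and a carbonyl carbon, the same change as that from compound 3 to compound 2, at the same place. For the measured compounds named here, the expectation for compound 4 rests on compound 1 at 50%, with a modest allowance for the change, since the only measured instance, no change at the digits printed from compound 3 to compound 2 (within the scatter), gives no guide from zero. The expected step of a number 10 percentage points lower from compound 1 to compound 4 (within the scatter) is therefore small. Compound 4 is expected to give 40% in this assay, between 10% and 70%.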

Compound 4, a percentage reported as activity, at one dose (the size of the read-out at that dose, not a potency): 100%
Compound 4: middle estimate off by 60 percentage points, on the low side; measured number above the stated range.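

In this assay, the change from ethyl to methyl on the core of compound 1 gives a number 50 percentage points higher from compound 1 to compound 4 (beyond the scatter), so this small change is not neutral on that core. For the compounds shown here, its effect did not carry over at the same size from one core to the other: the same change on two cores in this assay, no change at the digits printed (within the scatter) from compound 3 to compound 2 and a number 50 percentage points higher (beyond the scatter) from compound 1 to compound 4, 50 percentage points apart, beyond the scatter of two such steps This does not show that the change behaves differently on active and inactive cores in general, since compound 3 gives 0% and compound 2 gives 0%, which shows only that the change brings no measurable activity to that core at the one dose given, and two pairs support no rule for other cores.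

The compounds shown leave open how the read-out runs along the chain at this carbon, for instance with a propyl chain, or with hydrogen in place of the methyl of compound 4. They also leave open whether the result on the core of compound 4 holds with chlorine in place of its trifluoromethyl group.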